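This account rests on a few compounds, and the source may have more. Where it says the series, first, only, none or still open, it means among the compounds named here.

Measured so far in an assay on HEK293 cells for positive allosteric modulation of metabotropic glutamate receptor 3 (Rattus norvegicus), read by thallium flux, with a stated time of 2.5 min; a lower number here means a smaller maximal response, a higher number a larger maximal response:

Compound 1 `COC(=O)c1ccc(OCCCCOc2ccc(C(=O)CC3CCCC3)c(C)c2C)cc1`: 24.2%
Compound 2 `Cc1c(OCCCCOc2ccc(F)c(C(=O)O)c2)ccc(C(=O)CC2CCCC2)c1C`: 12.6%

Of these two numbers, compound 1 stands highest. Going by the values given here, its one neighbour, compound 2, lies below it, and the step of a number 11.6 percentage points lower from compound 1 to compound 2 (beyond the scatter) exchanges the aryl group at the far end of the chain, leaving the ketone side untouched.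

Compound 3 `COC(=O)c1ccc(OCCCCOc2ccc(C(=O)CC(C)C)c(C)c2C)cc1` is the unmeasured partner of compound 1. The change is isopropyl in place of cyclopentyl on a saturated chain carbon bound to a carbonyl carbon. Among the compounds with values here, this touches the ketone side of the molecule, a place that the only measured step does not reach, so no measured step bears directly on it, and the numbers offer no guide to its direction or size. In the absence of a relevant step, the expectation is a step within the usual scatter, a number 2.2 percentage points lower from compound 1 to compound 3 (within the scatter). For compound 3 the estimate is therefore 22%, expected to fall between 8% and 36%.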

Compound 3, largest response reached (reported as percent of maximum), in percent of the reference or control that the assay uses: 27.3%
The estimate for compound 3 lay 5.3 percentage points below the measured number; low and high end bracket the measured number.
By their numbers in this assay, from the lowest: compound 2; then compounds 1 and 3 (each within the scatter of the next).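

The ketone side of the molecule now has a measured step: in this assay, isopropyl in place of cyclopentyl on a saturated chain carbon bound to a carbonyl carbon gives a number 3.1 percentage points higher from compound 1 to compound 3 (within the scatter). Going from 5 heavy atoms with a ring to 3 heavy atoms with no ring therefore leaves the maximal response indistinguishable here, whereas the earlier exchange at the far end of the chain moved the number beyond the scatter. No measurement at hand speaks to why these two groups read alike.

As far as these compounds go, whether a phenyl ring, an amine or a longer chain at this place would also leave the response in the same range remains open. So does whether isopropyl would read the same alongside the 3-carboxy-4-fluorophenyl end of compound 2.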